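The source may hold more compounds than are shown below. What is called first, only, known or untested is meant among the compounds shown, and "the series" means these compounds.

In a functional assay on HeLa cells (Homo sapiens) for inhibition (a higher number here means a weaker inhibitor, a lower number a stronger inhibitor), compound 1 (`CC(C)c1ccc(C(=O)CC(SCC(=O)O)C(=O)O)cc1`) gives 3330 nM. Compound 2 (`CCCCCCCCCCCCc1ccc(C(=O)CC(SCC(=O)O)C(=O)O)cc1`) keeps the same core but carries a far longer chain, and it gives 1710 nM. Among the measured compounds shown here, these two values lie within the usual scatter of each other, so compound 1 stands level with the only other measured compound, and no order can be drawn between them.

Compound 3 (`O=C(O)CSC(CC(=O)c1ccc(Br)cc1)C(=O)O`) has not yet been measured. It differs from compound 1 as follows: bromo in place of isopropyl on an aromatic carbon. For the measured compounds named here, no measured pair shows this exchange directly, so the only guide is that compound 1 and compound 2 sit so close despite their very different chains. On that basis, no step beyond the scatter is expected in this assay, in either direction. The expected change is a 1.2-fold lower number from compound 1 to compound 3 (0.08 log units; within the scatter). Compound 3 is estimated at 2800 nM, with an expected range of 1000 nM to 7500 nM.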

Compound 3, half-maximal inhibitory concentration: 9500 nM
For compound 3 the middle estimate is 3.4-fold (0.53 log units) below the measured one; the whole stated range lies below it.
By their numbers in this assay, from the lowest: compounds 2 and 1 (each within the scatter of the next); then compound 3.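

Putting bromo in place of isopropyl on this aromatic carbon gives, in this assay, a 2.9-fold higher number from compound 1 to compound 3 (0.46 log units; beyond the scatter), so compound 3 is a modestly weaker inhibitor than compound 1. The two earlier compounds, which stand level despite their very different chains, gave no sign that a change at this place could move the number beyond the scatter; this step shows that it can. Nothing measured here accounts for the step.

From the compounds shown here alone, it remains open whether the weaker inhibition is specific to bromo or would also appear with another group at the same place, such as chloro, methoxy or an amine. It is also unknown whether a small carbon group such as methyl would stay level with compound 1 or move towards compound 3.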